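Methyl to hydrogen step carried across two cores

This account rests on a few compounds, and the source may have more. Where it says the series, first, only, none or still open, it means among the compounds named here.

Compound 1 `N/C(=N\NC(=S)N1CCCCCC1)c1ccccn1` gives 25.3% in a functional assay on MCF7 cells (Homo sapiens) for cytotoxicity, read by MTT assay, with a stated time of 72 h, tested at 1 uM; on this read-out higher numbers stand for more inhibition of growth at the one concentration tested and lower numbers for less inhibition of growth. Compound 2 `Cc1ccnc(/C(N)=N/NC(=S)N2CCCCCC2)c1` gives 18.2% in this assay. The step of a number 7.1 percentage points higher from compound 2 to compound 1 (within the scatter) goes with the change (hydrogen in place of methyl on an aromatic carbon). Compound 3 `Cc1cccc(/C(N)=N/NC(=S)N2CCCC2)n1` gives 17.4% in this assay; the difference between the core of compound 3 and the core of compound 2 is not broken down here. Compound 4 `N/C(=N\NC(=S)N1CCCC1)c1ccccn1` awaits measurement. It differs from compound 3 by hydrogen in place of methyl on an aromatic carbon, the same kind of change as that from compound 2 to compound 1, though the place differs: there the methyl sat opposite the ring nitrogen, here it sits next to the ring nitrogen. For the measured compounds named here, for compound 4 the step of a number 6.6 percentage points higher from compound 3 to compound 4 (within the scatter) is expected, set beside the measured a number 7.1 percentage points higher from compound 2 to compound 1 (within the scatter) as the only guide. Compound 4 is thus estimated at 24%, between 12% and 36%, because compound 3 stands at 17.4%.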

Compound 4, percent growth inhibition at one concentration: 45.9%
Compound 4: the middle estimate sits 21.9 percentage points below what was measured, outside the stated range (above it).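

Hydrogen in place of methyl on an aromatic carbon gives a number 28.5 percentage points higher from compound 3 to compound 4 (beyond the scatter) in this assay, and the size of this step does not carry over from one core to the other: the same change on two cores in this assay, a number 7.1 percentage points higher (within the scatter) from compound 2 to compound 1 and a number 28.5 percentage points higher (beyond the scatter) from compound 3 to compound 4, 21.4 percentage points apart, beyond the scatter of two such steps. Only the new step lies beyond the scatter, so the earlier pair does not establish a gain on its own core. The two pairs differ both in core and in the place of the methyl, and these compounds do not separate the two.

Open, on these data alone, is whether a methyl next to the ring nitrogen on the core of compound 1 would give a step of either size. Also open, as far as these compounds go, is how a methoxy, a chlorine or an amine on this aromatic carbon compares with methyl and hydrogen on either core.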